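Shrinking the side chain on the imidazole: compound 3 to compound 4

The source may hold more compounds than are shown below. What is called first, only, known or untested is meant among the compounds shown, and "the series" means these compounds.

For the measured compounds named here, the three compounds measured so far share one core and differ only in the group hanging from the five-membered ring. In an in vitro functional assay on cells for agonist activity at Bombesin receptor subtype-3 (Mus musculus), read by luminescence and calcium flux (a lower number here means that less compound is needed, a higher number that more compound is needed for the effect), compound 1 `COc1ccc(Cc2cnc(CCc3ccc(-c4ccccc4C(=O)O)cc3)[nH]2)cc1` gives 513 nM, compound 2 `O=C(O)c1ccccc1-c1ccc(CCc2ncc(CCc3ccccc3)[nH]2)cc1` gives 174 nM, and compound 3 `O=C(O)c1ccccc1-c1ccc(CCc2ncc(CCC3CCCCC3)[nH]2)cc1` gives 33 nM, the lowest of the three numbers. The steps that led there were a 16-fold lower number from compound 1 to compound 3 (1.19 log units; beyond the scatter) and a 5.3-fold lower number from compound 2 to compound 3 (0.72 log units; beyond the scatter), both pointing the same way: a saturated ring in place of a flat aromatic one lowered the number.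

Compound 4 `CC(C)(C)c1cnc(CCc2ccc(-c3ccccc3C(=O)O)cc2)[nH]1` takes a different direction: tert-butyl in place of 2-cyclohexylethyl on an aromatic carbon. Going by the values given here, no measured step removes the ring and shortens the chain at once, so the two steps above bear on it only loosely; they show that the identity of this group matters by a modest to large amount. Because the change takes away the 2-cyclohexylethyl group that gave a 5.3-fold lower number from compound 2 to compound 3 (0.72 log units; beyond the scatter), compound 4 is expected to need somewhat more compound, with the step of a 2.7-fold higher number from compound 3 to compound 4 (0.44 log units; beyond the scatter) estimated. The expected value for compound 4 in this assay is 90 nM, within a range of 25 nM to 350 nM.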

Compound 4, half-maximal effective concentration: 2750 nM
Compound 4: the middle estimate sits 31-fold (1.49 log units) below what was measured, outside the stated range (above it).
By their numbers in this assay, from the lowest: compound 3; then compound 2; then compound 1; then compound 4.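

In this assay, tert-butyl at this position on the five-membered ring gives an 83-fold higher number from compound 3 to compound 4 (1.92 log units; beyond the scatter), and the result is also unfavourable against the two aromatic side chains, with a 16-fold higher number from compound 2 to compound 4 (1.20 log units; beyond the scatter) and a 5.4-fold higher number from compound 1 to compound 4 (0.73 log units; beyond the scatter). So the position does not accept just any carbon group: among these four compounds, each side chain that carries a ring gives a lower number than tert-butyl, the only one without a ring, and no compound here goes against that. Nothing measured here explains this loss.

The change removes the ring and shortens the group in a single step, so these compounds cannot separate the two effects. Going by these compounds, how an open hexyl chain with no ring, or a cyclohexyl group set directly on the same aromatic carbon, would compare remains open.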